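Notes on the aryl variation at the chain carbon

The source may hold more compounds than are shown below. What is called first, only, known or untested is meant among the compounds shown, and "the series" means these compounds.

Compound 1 `O=C(O)c1ccc(C(=O)/C(=C\c2ccc(Br)cc2)SCc2ccc(Br)cc2)cc1` gives 1000 nM in a functional assay on DU-145 cells (Homo sapiens) for inhibition, read by trypan blue exclusion, with a stated time of 96 h; on this read-out lower numbers stand for stronger inhibition of growth and higher numbers for weaker inhibition of growth. Compound 2 `O=C(O)c1ccc(C(=O)/C(=C\c2ccc(O)c(Br)c2)SCc2ccc(Br)cc2)cc1` gives 25000 nM in this assay, and compound 3 `CN(C)c1ccc(/C=C(/SCc2ccc(Br)cc2)C(=O)c2ccc(C(=O)O)cc2)cc1` gives 50000 nM in this assay. Compound 3 thus carries the highest of the three numbers; its gap to compound 2 is within the scatter, while a 50-fold higher number from compound 1 to compound 3 (1.70 log units; beyond the scatter) sets it well apart from compound 1.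

The next entry, compound 4 `COc1cc(/C=C(/SCc2ccc(Br)cc2)C(=O)c2ccc(C(=O)O)cc2)ccc1F`, differs from compound 3 at one place: 4-fluoro-3-methoxyphenyl in place of 4-(dimethylamino)phenyl on a double-bonded chain carbon bound to a double-bonded chain carbon.

Among the compounds with values here, the steps that bear on this are the ones that swap the ring on that chain carbon: a 25-fold higher number from compound 1 to compound 2 (1.40 log units; beyond the scatter) and a 50-fold higher number from compound 1 to compound 3 (1.70 log units; beyond the scatter), with a 2.0-fold higher number from compound 2 to compound 3 (0.30 log units; within the scatter) between the two higher-number compounds. Across these three, the ring at this position goes with a wide span of numbers, the 4-bromophenyl of compound 1 at the strong end and the 3-bromo-4-hydroxyphenyl and 4-(dimethylamino)phenyl groups at the weak end. The 4-fluoro-3-methoxyphenyl entering in compound 4 matches neither directly; it carries a halogen like compound 1 and an oxygen substituent like compound 2. A moderate step toward lower numbers is therefore expected, a 5.0-fold lower number from compound 3 to compound 4 (0.70 log units; beyond the scatter), with wide uncertainty. Compound 4 is estimated at 10000 nM, range 2000 nM to 50000 nM.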

Compound 4, concentration for 50% growth inhibition: 1000 nM
For compound 4 the middle estimate is 10-fold (1.00 log units) above the measured one; the whole stated range lies above it.
By their numbers in this assay, from the lowest: compounds 1 and 4 (each within the scatter of the next); then compounds 2 and 3 (each within the scatter of the next).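

In this assay, no change at the digits printed from compound 1 to compound 4 (within the scatter) shows that the 4-bromophenyl group is not alone in giving a low number at this chain carbon, as 4-fluoro-3-methoxyphenyl places compound 4 level with compound 1. The same ring stands well apart from the two weaker groups, with a 50-fold lower number from compound 3 to compound 4 (1.70 log units; beyond the scatter) and a 25-fold lower number from compound 2 to compound 4 (1.40 log units; beyond the scatter), yet a halogen with an oxygen substituent does not sort the series: compound 2 carries that pairing too and stays at the weak end, and the counts printed for 4-(dimethylamino)phenyl and 4-fluoro-3-methoxyphenyl match in heavy atoms, donors, acceptors and charge despite the large step between them. No measurement on hand accounts for these steps.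

Going by these compounds, what remains open is which part of the 4-fluoro-3-methoxyphenyl group goes with the low number, and a 4-fluorophenyl or a 3-methoxyphenyl ring on this chain carbon would separate the two substituents. Also open, on these data alone, is how an unsubstituted phenyl ring compares here, and whether the match between compound 1 and compound 4 holds when the 4-bromobenzyl group on sulfur gives way to a longer chain.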